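A few compounds are considered here, and "the series" means these few. Any claim that something is new, unique, unknown or untested is made for them only; others in the source may bear on it.

Compound 3 `Cc1cc(N(C)Cc2ccccc2)nc(SCc2nc3ccccc3[nH]2)n1` is the point of departure here. In a functional assay on MCF7 cells (Homo sapiens) for cytotoxicity, read by MTT assay, with a stated time of 72 h (a higher number here means a weaker inhibitor, a lower number a stronger inhibitor), compound 3 gives > 100000 nM, which is a limit of the assay and not a number. Two companions share its core. Compound 1 `Cc1cc(N2CCCCC2)nc(SCc2nc3ccccc3[nH]2)n1` carries piperidin-1-yl at the same place, and in this assay compound 1 gives > 100000 nM, again only a limit. Within the data shown here, compound 2 `Cc1cc(Nc2ccc(Br)cc2)nc(SCc2nc3ccccc3[nH]2)n1` carries (4-bromophenyl)amino there, and in this assay compound 2 gives 38000 nM, the one real number of the three. So compound 3 sits at the top of what is shown, at the limit of > 100000 nM in this assay, at which 2 of the 3 values shown sit, where compound 1 also sits, while compound 2 stands clearly lower.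

The change to compound 4 `Cc1cc(Nc2ccc(F)cc2)nc(SCc2nc3ccccc3[nH]2)n1` is (4-fluorophenyl)amino in place of benzyl(methyl)amino on an aromatic carbon. The step that bears most directly on it is the reverse of a measured one: an at least 2.6-fold higher number from compound 2 to compound 3 (0.42 log units; beyond the scatter). In the same sense, an at least 2.6-fold lower number from compound 1 to compound 2 (0.42 log units; beyond the scatter), whereas a step that the two limits leave unreadable from compound 1 to compound 3. Whether fluorine or bromine on that ring matters is not tested by any pair here. Undoing the measured loss is therefore expected, with a step of an at least 2.2-fold lower number from compound 3 to compound 4 (0.34 log units; beyond the scatter). Compound 4 is expected to give about 45000 nM in this assay, with a plausible range from 15000 nM to 150000 nM.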

Compound 4, half-maximal inhibitory concentration: 42200 nM
For compound 4 the middle estimate is 1.1-fold (0.03 log units) above the measured one, and the stated range covers the measured number.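

The two halogens on the phenyl ring cannot be told apart in this assay: a 1.1-fold higher number from compound 2 to compound 4 (0.05 log units; within the scatter). The (4-fluorophenyl)amino group also stands clear of benzyl(methyl)amino, with an at least 2.3-fold lower number from compound 3 to compound 4 (0.37 log units; beyond the scatter), and of piperidin-1-yl, with an at least 2.3-fold lower number from compound 1 to compound 4 (0.37 log units; beyond the scatter), so a lower number at this position is now seen with two different phenylamino groups, whichever of the two halogens the ring carries. Compound 1 and compound 3 remain at a limit of the assay, which is not a number: the limit of > 100000 nM in this assay, at which 2 of the 4 values shown sit.

Going by these compounds, it stays open whether the lower numbers go with the hydrogen-bond donor that (4-fluorophenyl)amino carries and benzyl(methyl)amino does not, or with the phenyl ring sitting directly on that nitrogen, since the two differ in both respects. A plain phenylamino group without a halogen, a phenylamino group carrying methoxy or nitrile, or N-methyl-N-phenylamino, which keeps the ring but has no hydrogen on the nitrogen, would help to separate these possibilities.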